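The source may report more compounds than this note shows. Statements on the series, on what has been measured and on what is new or still open speak of the compounds shown alone.

In an assay for inhibition of serine/threonine-protein kinase Sgk1 (Homo sapiens), with stated times of 30 min and 60 min, in the presence of a further agent that is not named here (on this read-out higher numbers stand for weaker inhibition and lower numbers for stronger inhibition), compound 3, `Cc1n[nH]c2nc(-c3ccc(NS(=O)(=O)c4cc(Cl)ccc4F)cc3)nc(OC3CCOCC3)c12`, gives 5 nM, the lowest of the two numbers recorded, with compound 2, `Cc1n[nH]c2nc(-c3ccc(NS(=O)(=O)c4cc(Cl)ccc4F)cc3)nc(OCCC(=O)N(C)C)c12`, the nearest at 15 nM. Compound 1, `CCN1CCC(CNC(=O)c2cc(-c3ccc(NS(=O)(=O)c4cccc(Cl)c4Cl)cc3)nc3[nH]ncc23)C1`, sits at a limit of the assay, < 1 nM, which is the limit of < 1 nM in this assay, at which 1 of the 3 values shown sits. Among the measured compounds shown here, the only step measured between two numbers is a 3.0-fold lower number from compound 2 to compound 3 (0.48 log units; beyond the scatter), a modest gain at the same oxygen that is now changed again.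

Compound 4, `Cc1n[nH]c2nc(-c3ccc(NS(=O)(=O)c4cc(Cl)ccc4F)cc3)nc(OCC3CNCCO3)c12`, differs from compound 3 in one place: (morpholin-2-yl)methyl in place of oxan-4-yl on an oxygen on an aromatic ring. For the measured compounds named here, no measured pair shows this particular exchange, so the one step at this oxygen, a 3.0-fold lower number from compound 2 to compound 3 (0.48 log units; beyond the scatter), is the only guide, and it was modest. A change of about that size, or none beyond the scatter, is therefore expected; the direction is uncertain. Compound 4 is estimated to show 4 nM in this assay, with a range from 1.2 nM to 13 nM. The expected step is a 1.3-fold lower number from compound 3 to compound 4 (0.10 log units; within the scatter).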

Compound 4, half-maximal inhibitory concentration: 2 nM
Estimate against measurement, compound 4: 2.0-fold (0.30 log units) above, within the range that was stated.
By their numbers in this assay, from the lowest: compound 4; then compound 3; then compound 2. At a limit, below all of these: compound 1.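

The step at this oxygen repeats in the same direction, with a 2.5-fold lower number from compound 3 to compound 4 (0.40 log units; beyond the scatter), and the whole span from the amide chain is a 7.5-fold lower number from compound 2 to compound 4 (0.88 log units; beyond the scatter). So this position does more than tolerate change: among the three groups shown here, the one that carries a ring nitrogen and a hydrogen-bond donor gives the lowest number, and the oxan-4-yl ring is not the best group at this oxygen. Little room remains on this read-out for further gains to be resolved: the limit of < 1 nM in this assay, at which 1 of the 4 values shown sits.

The exchange changes two things at once, the ring nitrogen and the added methyl link, and the compounds shown do not separate them. A (oxan-4-yl)methyl group would test the link alone, and a tertiary amine such as (4-methylmorpholin-2-yl)methyl would test the hydrogen on the ring nitrogen.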